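The compounds below may be only part of what the source reports. "The series", "measured", "known", "first", "only" and "open" are said of these compounds alone.

Compounds measured so far in a functional assay on cells for agonist activity at Glucose-dependent insulinotropic receptor (Homo sapiens), read by a luciferase reporter, with a stated time of 4 h; on this read-out higher numbers stand for larger maximal responses and lower numbers for smaller maximal responses:

Compound 1, `CCc1cnc(N2CCC(c3coc4c(N5CCc6cc(S(C)(=O)=O)ccc65)ncnc34)CC2)nc1`: 154%
Compound 2, `Cn1cc(C2CCN(C(=O)OC(C)(C)C)CC2)c2ncnc(Nc3ccc(S(C)(=O)=O)cc3F)c21`: 3%
Compound 3, `CC(C)(C)OC(=O)N1CCC(c2csc3c(Nc4ccc(S(C)(=O)=O)cc4F)ncnc23)CC1`: 82%

Among these three, compound 1 stands highest in this assay. The nearest of the other two is compound 3, whose number lies a good way lower, beyond the usual scatter; the furthest is compound 2, whose number lies still further below. Compounds 2 and 3 differ from compound 1 in more than one place, so their values only show how far apart the three compounds lie, and no single change can be read out of them.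

For the measured compounds named here, the step to be followed is the one from compound 1 to compound 4, `COc1cnc(N2CCC(c3coc4c(N5CCc6cc(S(C)(=O)=O)ccc65)ncnc34)CC2)nc1`. The two differ in one place only: methoxy in place of ethyl on an aromatic carbon. The rest of compound 1 is carried over unchanged into compound 4.

Going by the values given here, no measured pair that differs in one place alone is available here, so the size of this step has no direct precedent in this assay. Since the whole of the remaining structure is retained, a small step is expected, with a slight downward lean, and the step from compound 1 to compound 4 is estimated at a number 14 percentage points lower from compound 1 to compound 4 (beyond the scatter). Compound 4 is therefore expected to give about 140% in this assay, within a range from 100% to 175%.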

Compound 4, largest response reached (Emax), in percent of the reference or control that the assay uses: 186%
Compound 4: middle estimate off by 46 percentage points, on the low side; measured number outside the range, above it.
By their numbers in this assay, from the lowest: compound 2; then compound 3; then compound 1; then compound 4.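

In this assay, for the compounds shown here, the change from 5-ethylpyrimidin-2-yl to 5-methoxypyrimidin-2-yl gives the first step at this position that can be read on its own, with the step reading a number 32 percentage points higher from compound 1 to compound 4 (beyond the scatter) and the rest of the structure unchanged. It shows that this aromatic carbon, two atoms from the ring nitrogen and para to a large group, is a place where the maximal response can still move upward, even for an exchange that keeps the count of heavy atoms and adds one hydrogen-bond acceptor. Nothing measured here bears on why the number moves in this way.

The compounds shown leave open whether this rise belongs to the oxygen atom or to the methoxy group as a whole, and how an ethoxy group, a dimethylamino group or a nitrile would behave on the same carbon. From the compounds shown here alone, it also remains open whether methoxy in place of ethyl would give a step of similar size on a different core, or with a different group in place of the pyrimidine ring's neighbours in the shared structure.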